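A few compounds are considered here, and "the series" means these few. Any claim that something is new, unique, unknown or untested is made for them only; others in the source may bear on it.

Compound 1 `COc1cc(/C=C/C(=O)/C=C/c2cccc3ccccc23)ccc1OCc1cn(CCOc2cc(=O)oc3ccccc23)nn1` holds the highest of the three numbers recorded so far: in a functional assay on HCT-116 cells (Homo sapiens) for cytotoxicity, read by sulforhodamine B assay, with a stated time of 48 h (on this read-out higher numbers stand for weaker inhibition and lower numbers for stronger inhibition), compound 1 gives 6540 nM. Compound 2 `COc1cc(/C=C/C(=O)/C=C/c2cc(OC)c(OC)c(OC)c2)ccc1OCc1cn(CCOc2cc(=O)oc3ccccc23)nn1` gives 2210 nM, and compound 3 `COc1ccc(/C=C/C(=O)/C=C/c2ccc(OCc3cn(CCOc4cc(=O)oc5ccccc45)nn3)c(OC)c2)cc1OC` gives 4710 nM. Compound 4 `COc1cc(/C=C/C(=O)/C=C/c2ccco2)ccc1OCc1cn(CCOc2cc(=O)oc3ccccc23)nn1` differs from compound 1 in a single place: furan-2-yl in place of naphthalen-1-yl on a double-bonded chain carbon bound to a double-bonded chain carbon. Among the compounds with values here, two measured steps bear on this change, since each also replaces the naphthalen-1-yl at the same place: a 3.0-fold lower number from compound 1 to compound 2 (0.47 log units; beyond the scatter) and a 1.4-fold lower number from compound 1 to compound 3 (0.14 log units; within the scatter). Both point toward lower numbers, one beyond the scatter and one within it. A step of similar size and direction is therefore expected here, namely a 1.6-fold lower number from compound 1 to compound 4 (0.21 log units; within the scatter). Compound 4 is estimated in this assay at 4000 nM, with a likely range from 1500 nM to 10000 nM.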

Compound 4, half-maximal inhibitory concentration: 9180 nM
Compound 4: the middle estimate sits 2.3-fold (0.36 log units) below what was measured; low and high end bracket the measured number.
By their numbers in this assay, from the lowest: compound 2; then compounds 3, 1 and 4 (each within the scatter of the next).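

Replacing naphthalen-1-yl at this place does not by itself lower the number in this assay: with furan-2-yl, the change stays within the scatter (a 1.4-fold higher number from compound 1 to compound 4 (0.15 log units; within the scatter)). Furan-2-yl also stays within the scatter of 3,4-dimethoxyphenyl (a 1.9-fold higher number from compound 3 to compound 4 (0.29 log units; within the scatter)), while only 3,4,5-trimethoxyphenyl stands clearly apart from it (a 4.2-fold higher number from compound 2 to compound 4 (0.62 log units; beyond the scatter)). From the compounds shown here alone, what a phenyl ring carrying an amine or a carboxylic acid would give at this place remains open. Nothing available here explains why these groups differ.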